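This account rests on a few compounds, and the source may have more. Where it says the series, first, only, none or still open, it means among the compounds named here.

Two measured members of the series are known. Compound 1 `Cc1nc2c(OCc3ccccc3)ccc(C)n2c1C` gives 26% in a functional assay on the whole organism with Rattus norvegicus as the target, at a dose of 40 mg/kg by the intraperitoneal route; on this read-out higher numbers stand for more inhibition at the one dose given (going by the name of the read-out) and lower numbers for less inhibition. Compound 2 `Cc1nc2c(OCc3ccccc3)cccn2c1NC=O` gives 49% in this assay, the higher of the two numbers, above compound 1 by a gap beyond the scatter. Compound 3 `CCNc1c(C)nc2c(OCc3ccccc3)cccn12` has not yet been measured; it differs from compound 2 by ethyl in place of formyl on a nitrogen on an aromatic ring. Going by the values given here, no measured pair shows the effect of exchanging formyl for ethyl, so the direction is open; a modest fall in this assay is expected for compound 3, a number 12 percentage points lower from compound 2 to compound 3 (beyond the scatter), of a size about at the edge of the scatter. Compound 3 is accordingly estimated at 37%, within 12% to 60%.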

Compound 3, a percentage reported as inhibition, in the whole organism at one dose (the size of the read-out at that dose, not a potency): 95%
For compound 3 the middle estimate is 58 percentage points below the measured one; measured number outside the range, above it.
By their numbers in this assay, from the lowest: compound 1; then compound 2; then compound 3.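

In this assay, going by these compounds alone, ethyl in place of formyl on a nitrogen on an aromatic ring gives a number 46 percentage points higher from compound 2 to compound 3 (beyond the scatter) and is the first measured exchange at this place. The number at this place therefore responds strongly to the group on that nitrogen, and the hydrogen-bond acceptor and the carbonyl of formyl are not required for high inhibition at this dose. Nothing available accounts for the size of this step.

From the compounds shown here alone, whether a longer chain such as propyl on this nitrogen would hold the number stays open. So does the behaviour of the unsubstituted amine.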